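Replacing an acyl cap with a sulfonyl cap on compound 3

A few compounds are considered here, and "the series" means these few. Any claim that something is new, unique, unknown or untested is made for them only; others in the source may bear on it.

Compound 3 `CN1CCN(c2ccc(Nc3ncc4nc(Nc5ccc(F)cc5)n([C@H]5CCN(C(=O)CO)C5)c4n3)cc2)CC1` is measured in a functional assay on HCC827 cells (Homo sapiens) for antiproliferative activity, read by MTT assay, with a stated time of 72 h (a higher number here means a weaker inhibitor, a lower number a stronger inhibitor), where it gives 380 nM. Among the three measured compounds it stands second highest: compound 1 `CN1CCN(c2ccc(Nc3ncc4nc(Nc5ccc(F)cc5)n([C@H]5CCNC5)c4n3)cc2)CC1` gives 1220 nM, and compound 2 `CC(=O)Nc1cccc(-n2c(Nc3ccc(F)cc3)nc3cnc(Nc4ccc(N5CCN(C)CC5)cc4)nc32)c1` gives 10 nM. The step of a 3.2-fold lower number from compound 1 to compound 3 (0.51 log units; beyond the scatter) is the only one that keeps the shared core and the pyrrolidine ring and changes just the group on its ring nitrogen; the steps of a 120-fold lower number from compound 1 to compound 2 (2.09 log units; beyond the scatter) and a 38-fold higher number from compound 2 to compound 3 (1.58 log units; beyond the scatter) exchange the whole substituent on the aromatic nitrogen and are of a different kind.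

Compound 4 `CN1CCN(c2ccc(Nc3ncc4nc(Nc5ccc(F)cc5)n([C@@H]5CCN(S(=O)(=O)C6CC6)C5)c4n3)cc2)CC1` is not yet measured. It differs from compound 3 by 1-(cyclopropylsulfonyl)pyrrolidin-3-yl in place of 1-((hydroxymethyl)carbonyl)pyrrolidin-3-yl on an aromatic nitrogen. Going by the values given here, no measured step bears directly on this change: the only comparison on the ring nitrogen is the modest step of a 3.2-fold lower number from compound 1 to compound 3 (0.51 log units; beyond the scatter), which went from hydrogen to the (hydroxymethyl)carbonyl group rather than between two capped forms. With compound 3 at 380 nM as the anchor and no evidence that a different group on the ring nitrogen moves the number, compound 4 is expected to stay in the same region, with a 1.1-fold higher number from compound 3 to compound 4 (0.02 log units; within the scatter) as the estimated step. Compound 4 is therefore estimated at 400 nM, with a range of 120 nM to 1500 nM.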

Compound 4, half-maximal inhibitory concentration: 2.5 nM
Estimate against measurement, compound 4: 160-fold (2.20 log units) above, and the stated range ends above it.
By their numbers in this assay, from the lowest: compound 4; then compound 2; then compound 3; then compound 1.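

The group on the ring nitrogen of the pyrrolidin-3-yl substituent turns out to matter far more than the earlier comparison suggested: a 150-fold lower number from compound 3 to compound 4 (2.18 log units; beyond the scatter) shows that exchanging one cap for another can outweigh adding the first cap to the free ring nitrogen, and a 490-fold lower number from compound 1 to compound 4 (2.69 log units; beyond the scatter) is the widest step in this set. A 3-acetamidophenyl group is also not required on the aromatic nitrogen for a low number: with a 4.0-fold lower number from compound 2 to compound 4 (0.60 log units; beyond the scatter), a capped pyrrolidine passes it, whereas compound 1 and compound 3 both stood well above compound 2. No available data account for the size of this change.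

As written, the structures of compound 3 and compound 4 carry opposite configurations at their defined stereocentre, so the compounds shown cannot separate the effect of the cyclopropylsulfonyl cap from that of the inverted centre. Going by these compounds, it also remains open how a cyclopropylcarbonyl or a methylsulfonyl group on the same ring nitrogen would read, which would show whether the sulfonyl unit or the cyclopropyl ring carries the change.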